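From 4-Fluorophenyl to 2-Fluorophenyl

A few compounds are considered here, and "the series" means these few. Any claim that something is new, unique, unknown or untested is made for them only; others in the source may bear on it.

Of the compounds shown here, three with a shared core have been measured in a functional assay on HT-29 cells (Homo sapiens) for antiproliferative activity, read by MTT assay, with a stated time of 72 h; on this read-out higher numbers stand for weaker inhibition and lower numbers for stronger inhibition. Compound 1 `Nc1nc(N)c2cc(CSC(=S)N3CCN(c4ccccc4)CC3)ccc2n1` gives 2760 nM, compound 2 `Nc1nc(N)c2cc(CSC(=S)N3CCN(c4ccc(Cl)cc4)CC3)ccc2n1` gives 7480 nM, and compound 3 `Nc1nc(N)c2cc(CSC(=S)N3CCN(c4ccc(F)cc4)CC3)ccc2n1` gives 2050 nM. The data show a 1.3-fold lower number from compound 1 to compound 3 (0.13 log units; within the scatter), so that pair cannot be told apart. Compound 3 does stand clear of the chloro compound, with a 3.6-fold lower number from compound 2 to compound 3 (0.56 log units; beyond the scatter).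

Compound 4 `Nc1nc(N)c2cc(CSC(=S)N3CCN(c4ccccc4F)CC3)ccc2n1` keeps the same atoms: 2-fluorophenyl in place of 4-fluorophenyl on an amine nitrogen in a ring. This places 2-fluorophenyl in place of 4-fluorophenyl on an amine nitrogen in a ring. Among the measured compounds shown here, no measured step makes this kind of change, so the evidence is indirect. The closest guide is fluoro in place of hydrogen, with a 1.3-fold lower number from compound 1 to compound 3 (0.13 log units; within the scatter). Chloro in place of hydrogen gave a modest change, with a 2.7-fold higher number from compound 1 to compound 2 (0.43 log units; beyond the scatter), so some movement cannot be ruled out. A step within the scatter is therefore expected, with no firm direction, and the estimate is a 1.2-fold higher number from compound 3 to compound 4 (0.07 log units; within the scatter). For compound 4 the expected value is 2400 nM, with an estimated range of 1100 nM to 5500 nM.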

Compound 4, half-maximal inhibitory concentration: 5420 nM
For compound 4 the middle estimate is 2.3-fold (0.35 log units) below the measured one, within the range that was stated.
By their numbers in this assay, from the lowest: compounds 3, 1, 4 and 2 (each within the scatter of the next, the first and the last beyond it).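

In this assay, the result shows that the place of the fluorine on the phenyl ring can matter even though the atoms stay the same: a 2.6-fold higher number from compound 3 to compound 4 (0.42 log units; beyond the scatter). The earlier compounds shown here showed only that fluoro in place of hydrogen on the 4-fluorophenyl compound could not be told from the unsubstituted phenyl. Compound 4 does not stand clear of its other neighbours, with a 2.0-fold higher number from compound 1 to compound 4 (0.29 log units; within the scatter) and a 1.4-fold lower number from compound 2 to compound 4 (0.14 log units; within the scatter), so only compound 3 is separated from it. No measurement given here explains this difference.

Going by these compounds, with a single pair of fluorine placements, it remains open whether the difference reflects fluorine alone or would recur with other groups. A methoxy or nitrile group on the phenyl ring could test that.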